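Removing the bromo from compound 2: working notes

A few compounds are considered here, and "the series" means these few. Any claim that something is new, unique, unknown or untested is made for them only; others in the source may bear on it.

Values in a functional assay on thoracic aorta (Rattus norvegicus, strain Wistar), with a stated time of 15 min; on this read-out higher numbers stand for an effect only at larger amounts of compound and lower numbers for an effect already at smaller amounts:
- compound 1 `Cc1ccc(S(=O)(=O)NC(=O)NC(C)c2ccccc2OCc2ccccc2)cc1`: > 200000 nM, a limit of the assay and not a number
- compound 2 `CC(NC(=O)NS(=O)(=O)c1ccccc1)c1cc(Br)ccc1OCc1ccccc1`: 130000 nM
- compound 3 `Cc1ccc(S(=O)(=O)NC(=O)NC(C)c2cc(Br)ccc2OCc2ccccc2)cc1`: 138000 nM
- compound 4 `CC(NC(=O)NS(=O)(=O)c1ccccc1)c1ccccc1OCc1ccccc1`: not yet measured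

Among the compounds with values here, compound 2 stands at 130000 nM, and its one numerical neighbour lies within the scatter, with a 1.1-fold higher number from compound 2 to compound 3 (0.03 log units; within the scatter). The next change is hydrogen in place of bromo on an aromatic carbon.

The closest evidence is the same exchange read in reverse, in the methyl pair, which gives an at least 1.4-fold lower number from compound 1 to compound 3 (0.16 log units; that floor lies within the scatter). That step starts from a limit: the limit of > 200000 nM in this assay, at which 1 of the 3 values shown sits. The methyl exchange itself showed no effect beyond the scatter, so compound 4 is expected to sit close to compound 1. In this assay a higher number is therefore expected, possibly one reported only as a limit. The expected step is a 1.7-fold higher number from compound 2 to compound 4 (0.23 log units; within the scatter), and it may not clear the scatter. For compound 4 the estimated value is 220000 nM, with an expected range of 120000 nM to 500000 nM.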

Compound 4, half-maximal effective concentration: > 200000 nM
Compound 4: only a limit was reported (the forecaster's own chance of this, stated with the estimate: 60%); the middle value is on the limit's open side.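

In this assay, hydrogen in place of bromo on the aromatic carbon para to a benzyloxy group gives an at least 1.5-fold higher number from compound 2 to compound 4 (0.18 log units; that floor lies within the scatter). The bromo exchange can now be read on two cores, and on both the reading rests on a limit, so neither shows a step beyond the scatter: the same change on two cores in this assay, an at least 1.4-fold lower number (0.16 log units; that floor lies within the scatter) from compound 1 to compound 3 and an at least 1.5-fold lower number (0.18 log units; that floor lies within the scatter) from compound 4 to compound 2; the limit leaves it open whether they differ The step between compound 1 and compound 4, hydrogen in place of methyl, cannot be read, as both values are limits of the assay and not numbers: the limit of > 200000 nM in this assay, at which 2 of the 4 values shown sit.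

Going by these compounds, how far the true value of compound 4 lies from that of compound 2 stays open, and with it whether the bromo matters beyond the scatter on either core. Also open, on these data alone, is what a chloro or an amine in place of the bromo would give at this position.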